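A few compounds are considered here, and "the series" means these few. Any claim that something is new, unique, unknown or untested is made for them only; others in the source may bear on it.

Of the compounds shown here, three with one shared core have been measured so far. In a functional assay for inhibition of sodium/hydrogen exchanger (Oryctolagus cuniculus) (on this read-out higher numbers stand for weaker inhibition and lower numbers for stronger inhibition), compound 1 `CCc1cc(C)c(C(=O)N=C(N)N)cc1S(C)(=O)=O` gives 4.8 nM, and compound 2 `CSc1cc(C)c(C(=O)N=C(N)N)cc1S(C)(=O)=O` gives 6 nM; the step of a 1.3-fold higher number from compound 1 to compound 2 (0.10 log units; within the scatter) shows that these two substituents make no difference that can be trusted. Compound 3 `Cc1cc(OC2CCCC2)c(S(C)(=O)=O)cc1C(=O)N=C(N)N`, which carries a cyclopentyloxy group at the same aromatic carbon, gives 27 nM in this assay, the highest of the three numbers and thus the weakest inhibition seen here, as the steps of a 5.6-fold higher number from compound 1 to compound 3 (0.75 log units; beyond the scatter) and a 4.5-fold higher number from compound 2 to compound 3 (0.65 log units; beyond the scatter) make plain.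

The next compound, compound 4 `Cc1cc(C(F)(F)F)c(S(C)(=O)=O)cc1C(=O)N=C(N)N`, differs from compound 3 in one place: trifluoromethyl in place of cyclopentyloxy on an aromatic carbon

The two steps that bear on this are those leading to compound 3, in which a cyclopentyloxy group replaced a smaller group and the number rose modestly. Going back from the six-heavy-atom ring to a four-heavy-atom group without a ring is expected to reverse that, so a modest drop in this assay is the estimate, with the step of a 3.4-fold lower number from compound 3 to compound 4 (0.53 log units; beyond the scatter). For compound 4 the expected value in this assay is therefore 8 nM, within a range from 3 nM to 25 nM.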

Compound 4, half-maximal inhibitory concentration: 37 nM
The estimate for compound 4 lay 4.6-fold (0.67 log units) below the measured number, outside the stated range (above it).
By their numbers in this assay, from the lowest: compounds 1 and 2 (each within the scatter of the next); then compounds 3 and 4 (each within the scatter of the next).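

In this assay, trifluoromethyl and cyclopentyloxy at this aromatic carbon cannot be told apart (a 1.4-fold higher number from compound 3 to compound 4 (0.14 log units; within the scatter)), even though trifluoromethyl has fewer heavy atoms and no ring, so heavy-atom count alone does not set the number here. Trifluoromethyl differs clearly from the other two groups at this position (a 6.2-fold higher number from compound 2 to compound 4 (0.79 log units; beyond the scatter); a 7.7-fold higher number from compound 1 to compound 4 (0.89 log units; beyond the scatter)), which divides the four compounds into two pairs: compounds 1 and 2 with the lower numbers, compounds 3 and 4 with the higher. No measurement here accounts for this division.

The compounds shown leave open where an amine, a carboxylic acid or a longer alkyl chain at this carbon would fall. They also leave open whether a methoxy group or a chlorine atom would join compounds 1 and 2 or compounds 3 and 4.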